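This account rests on a few compounds, and the source may have more. Where it says the series, first, only, none or still open, it means among the compounds named here.

Compound 3 `CCOC(=O)[C@]1(C(=O)NCc2ccc(C)cc2)C[C@H]1c1cc(OC)c(OC)c(OC)c1` gives in a functional assay on K562 cells (Homo sapiens) for cytotoxicity, read by MTT assay, with a stated time of 48 h (a higher number here means a weaker inhibitor, a lower number a stronger inhibitor), only a limit of the assay, > 100000 nM, so no single number is known for it. Compound 1 `CCOC(=O)C1(C(=O)NCc2ccc(C)cc2)CC1c1cc(OC)c(OC)c(OC)c1` likewise reaches only a limit in this assay, > 100000 nM; > 100000 nM (2 entries). Compound 2 `COc1cc([C@H]2C[C@@]2(CO)C(=O)NCc2ccc(C)cc2)cc(OC)c1OC` too sits at a limit in this assay, > 100000 nM. Compound 3 therefore stands where the other values stand, at the limit (the limit of > 100000 nM in this assay, at which 2 of the 3 values shown sit), with no measurable difference among the three.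

Compound 4 `COc1cc([C@@H]2C[C@]2(CO)C(=O)NCc2ccc(C)cc2)cc(OC)c1OC` differs from compound 3 by hydroxymethyl in place of ethoxycarbonyl on a saturated ring carbon. For the measured compounds named here, with no measured step to lean on, the expected step that the limit leaves unreadable from compound 3 to compound 4 in this assay is none beyond the usual scatter, in either direction. Compound 4 is thus estimated at 150000 nM, within a range from 50000 nM to 500000 nM, and most probably again only a limit.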

Compound 4, half-maximal inhibitory concentration: > 100000 nM
Compound 4 ended at the assay's limit (the forecaster's own chance of this, stated with the estimate: 85%); the middle value does not contradict the limit.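

For the compounds shown here, neither the step from compound 3 to compound 4 nor the one from compound 2 to compound 4 can be read in this assay: the limit of > 100000 nM in this assay, at which 3 of the 4 values shown sit. Whether the hydroxymethyl group or the configuration as drawn matters for potency stays open, as none of the compounds shown gives a single number.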